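The source may hold more compounds than are shown below. What is called first, only, known or untested is meant among the compounds shown, and "the series" means these compounds.

Measured so far:
compound 1 `O=C(CN1CCNCC1)N1CCC(NS(=O)(=O)c2cc(S(=O)(=O)c3ccccc3)ccc2C(F)(F)F)CC1` — 140 nM
compound 2 `CC(=O)N1CCC[C@H]1C(=O)N1CCC(NS(=O)(=O)c2cc(S(=O)(=O)c3ccccc3)ccc2C(F)(F)F)CC1` — 160 nM

In an assay on isolated protein for binding affinity to secreted frizzled-related protein 1 (Homo sapiens), read by fluorescence (a lower number here means a stronger inhibitor, a higher number a weaker inhibitor), compound 1 gives 140 nM, the lower of the two numbers, with compound 2 nearest at 160 nM. The change to compound 3 `O=C([C@@H]1CCCN1Cc1ccccc1)N1CCC(NS(=O)(=O)c2cc(S(=O)(=O)c3ccccc3)ccc2C(F)(F)F)CC1` is 1-benzylpyrrolidin-2-yl in place of (piperazin-1-yl)methyl on a carbonyl carbon. Among the compounds with values here, the one step that bears on it is a 1.1-fold higher number from compound 1 to compound 2 (0.06 log units; within the scatter), where a pyrrolidin-2-yl group also replaced the (piperazin-1-yl)methyl group on the carbonyl carbon. On that basis the step of a 1.1-fold higher number from compound 1 to compound 3 (0.03 log units; within the scatter) is expected to stay within the scatter. For compound 3 the estimate is 150 nM, with a range from 60 nM to 400 nM.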

Compound 3, half-maximal inhibitory concentration: 1400 nM
Compound 3: middle estimate off by 9.3-fold (0.97 log units), on the low side; measured number above the stated range.
By their numbers in this assay, from the lowest: compounds 1 and 2 (each within the scatter of the next); then compound 3.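

In this assay the group on this carbonyl carbon is not free to vary: 1-benzylpyrrolidin-2-yl brings a 10-fold higher number from compound 1 to compound 3 (1.00 log units; beyond the scatter) and moves the number beyond the scatter, unlike the 1-acetylpyrrolidin-2-yl of compound 2. With the pyrrolidin-2-yl kept, benzyl in place of acetyl on the ring amine nitrogen gives an 8.8-fold higher number from compound 2 to compound 3 (0.94 log units; beyond the scatter) and so the rise follows the substituent on that nitrogen, not the pyrrolidin-2-yl alone. No evidence on hand accounts for the rise.

As far as these compounds go, whether a methyl group or a bare amine hydrogen on that nitrogen reads like acetyl or like benzyl stays open. So does whether a cyclohexylmethyl group there would match benzyl.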